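Solubility notes: cyclohexylmethyl for 4-fluorophenyl on the core

The source may hold more compounds than are shown below. What is called first, only, known or untested is meant among the compounds shown, and "the series" means these compounds.

Measured so far in a physicochemical assay for solubility, with a stated time of 18 h, at pH 7.4; a higher number here means a more soluble compound, a lower number a less soluble compound:
compound 1 `Fc1ccc(-c2ccc3c(NCCCNCc4ccco4)ccnc3c2)cc1`: 32000 nM
compound 2 `COc1ccc(F)cc1CNCCCNc1ccnc2cc(-c3ccc(F)cc3)ccc12`: 32000 nM
compound 3 `COc1cccc(CNCCCNc2ccnc3cc(Oc4cccc(N(C)C)c4)ccc23)c1O`: 14500 nM

Compound 1 stands level with compound 2, and compound 3 lies below both. Within the data shown here, the one step with a single change, no change at the digits printed from compound 1 to compound 2 (within the scatter), alters the group on the saturated chain carbon bound to the amine nitrogen and leaves this assay unchanged within the scatter.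

Compound 4 `c1coc(CNCCCNc2ccnc3cc(CC4CCCCC4)ccc23)c1` is not yet measured. Its change from compound 1 is cyclohexylmethyl in place of 4-fluorophenyl on an aromatic carbon. Among the measured compounds shown here, no measured step touches this position, and compound 3 differs from compound 1 in several places at once, so nothing here indicates the direction. The step of a 1.3-fold lower number from compound 1 to compound 4 (0.11 log units; within the scatter) is therefore expected to stay within the scatter, with a wide range. Compound 4 is estimated at 25000 nM, between 8000 nM and 70000 nM.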

Compound 4, solubility: 4200 nM
Estimate against measurement, compound 4: 6.0-fold (0.77 log units) above; measured number below the stated range.
By their numbers in this assay, from the lowest: compound 4; then compound 3; then compounds 1 and 2 (each within the scatter of the next).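

The aromatic carbon carrying 4-fluorophenyl matters in this assay: cyclohexylmethyl there gives a 7.6-fold lower number from compound 1 to compound 4 (0.88 log units; beyond the scatter), a step the earlier chain-end change did not show. The two groups have equal heavy-atom and hydrogen-bond donor and acceptor counts, so those counts do not separate them. No measurement at hand accounts for this step. The compounds shown leave open how benzyl or cyclohexyl would compare at this position, which would separate the non-aromatic ring from the methylene link. Going by these compounds, whether an amine on the cyclohexyl ring would shift the number also remains open.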